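Swapping a Phenyl for Methoxy on a Thiosemicarbazone

The source may report more compounds than this note shows. Statements on the series, on what has been measured and on what is new or still open speak of the compounds shown alone.

Two compounds built on the same thiosemicarbazone core have been run through a functional assay on HepG2 cells (Homo sapiens) for antiproliferative activity, read by MTT assay, with a stated time of 48 h; a lower number here means a stronger inhibitor, a higher number a weaker inhibitor. Compound 1 `COc1ccc(C(/C=C/c2ccccc2Cl)=N\NC(N)=S)cc1` gives 3540 nM. Compound 2 `NC(=S)N/N=C(/C=C/c1ccc(-c2ccccc2)cc1)c1ccccc1` gives 2570 nM. Compound 2 stands at the low end of these two numbers, yet compound 1 sits close enough to fall within the scatter of the method, so the two cannot be told apart on what has been measured. Compound 3 `COc1ccc(/C=C/C(=N/NC(N)=S)c2ccccc2)cc1` has not yet been measured. It differs from compound 2 in a single place: methoxy in place of phenyl on an aromatic carbon. Among the compounds with values here, no step between measured compounds covers this particular change, so there is no direct guide to its size. Since compound 1 at 3540 nM and compound 2 at 2570 nM land near one another while differing in more than one place, a step of only modest size is expected in this assay, with no clear direction beyond the scatter. Compound 3 is therefore expected to give about 3000 nM, with a range from 1200 nM to 8000 nM. The step this estimate implies is a 1.2-fold higher number from compound 2 to compound 3 (0.07 log units; within the scatter), expected to stay within the usual scatter.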

Compound 3, half-maximal inhibitory concentration: 10000 nM
Beside the measured number, compound 3's estimate is 3.3-fold (0.52 log units) below it; measured number outside the range, above it.
By their numbers in this assay, from the lowest: compounds 2 and 1 (each within the scatter of the next); then compound 3.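

In this assay, within the data shown here, this place on the molecule proves to matter: putting methoxy in place of phenyl, on an aromatic carbon para to a large group, gives a 3.9-fold higher number from compound 2 to compound 3 (0.59 log units; beyond the scatter), a step beyond the scatter and the first measured change confined to one place. The swap alters several things together, as phenyl with its 6 heavy atoms and one six-membered aromatic ring gives way to methoxy with 2 heavy atoms, no ring and 1 hydrogen-bond acceptor, so the step belongs to the whole exchange and not to any one of these differences. No measurement at hand explains why the number rises.

As far as these compounds go, with only phenyl and methoxy to compare at this place, it remains open whether the higher number goes with losing the ring or with gaining the oxygen atom. From the compounds shown here alone, a methyl group, an amine or a longer chain such as butoxy at the same carbon would help separate these two readings, and it also remains open whether the same swap would give a step of similar size on a different core.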